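The source may hold more compounds than are shown below. What is called first, only, known or untested is meant among the compounds shown, and "the series" means these compounds.

Three compounds share one core and differ only in the group hung from it. Compound 1 `Nc1cc(N)c2nc(-c3ccccc3)c(NCc3ccc(Cl)c(Cl)c3)nc2c1` gives 6920 nM in a functional assay on OVCAR-3 cells (Homo sapiens) for inhibition, read by sulforhodamine B assay, with a stated time of 48 h; on this read-out lower numbers stand for stronger inhibition of growth and higher numbers for weaker inhibition of growth. Compound 2 `COc1ccc(CNc2nc3cc(N)cc(N)c3nc2-c2ccccc2)cc1OC` gives 3310 nM in this assay, and compound 3 `Nc1cc(N)c2nc(-c3ccccc3)c(NCc3ccc(F)cc3)nc2c1` gives 6460 nM in this assay. Of these three numbers compound 3 holds the second highest; its nearest neighbour is compound 1 and compound 2 is furthest off, yet both of those gaps lie within the scatter, so no real order among the three can be read from them. The steps measured so far are a 2.1-fold lower number from compound 1 to compound 2 (0.32 log units; beyond the scatter), a 1.1-fold lower number from compound 1 to compound 3 (0.03 log units; within the scatter) and a 2.0-fold higher number from compound 2 to compound 3 (0.29 log units; within the scatter); each of them exchanges the aryl group carried on a saturated chain carbon bound to a nitrogen on an aromatic ring, and none of them alters the link itself.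

Compound 4 `Nc1cc(N)c2nc(-c3ccccc3)c(Oc3ccc(F)cc3)nc2c1` takes a different kind of step: 4-fluorophenoxy in place of (4-fluorobenzyl)amino on an aromatic carbon. Going by the values given here, no measured step touches this link, so none of them bears on the change, and the only guide is that the three measured numbers sit close together. The expected step is therefore a 1.1-fold higher number from compound 3 to compound 4 (0.03 log units; within the scatter), with no direction beyond the scatter that the data could justify. Compound 4 is estimated at 7000 nM in this assay, within a range from 2000 nM to 25000 nM.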

Compound 4, concentration for total growth inhibition: 41700 nM
For compound 4 the middle estimate is 6.0-fold (0.78 log units) below the measured one; the whole stated range lies below it.
By their numbers in this assay, from the lowest: compounds 2, 3 and 1 (each within the scatter of the next, the first and the last beyond it); then compound 4.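

Changing the link itself gives a 6.5-fold higher number from compound 3 to compound 4 (0.81 log units; beyond the scatter) in this assay, a larger step than any exchange of the aryl group, of which the largest is a 2.1-fold lower number from compound 1 to compound 2 (0.32 log units; beyond the scatter), so at this position the link matters more than the aryl groups tried so far. The change is not a single swap, though: (4-fluorobenzyl)amino, with 9 heavy atoms and 1 hydrogen-bond donor, gives way to 4-fluorophenoxy, with 8 heavy atoms and 0 donors, so the saturated chain carbon and the nitrogen with its hydrogen leave together, and this one step cannot tell which loss accounts for the weaker inhibition of growth. Nothing available explains why the number rises at this position.

Still open, on these data alone, is where a 4-fluorobenzyloxy group, which keeps the chain carbon but has oxygen in the link, or a 4-fluoroanilino group, which keeps the nitrogen but drops the chain carbon, would fall relative to compound 3 and compound 4. Also open, as far as these compounds go, is whether a sulfur link would behave like the oxygen link, and whether the step would keep its size with the 3,4-dimethoxyphenyl group of compound 2.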